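A few compounds are considered here, and "the series" means these few. Any claim that something is new, unique, unknown or untested is made for them only; others in the source may bear on it.

Compound 1 `Cc1ccc(-c2n[nH]c(-c3ccccc3C)n2)cc1` was examined in a functional assay on the whole organism (Cricetulus griseus) with Cricetinae gen. sp. as the target (a higher number here means that more compound is needed for the effect, a lower number that less compound is needed), where compound 1 gives 20 mg/kg, the highest of the two numbers recorded so far. Its nearest neighbour is compound 2 `Cc1ccccc1-c1n[nH]c(-c2ccc(Cl)cc2)n1`, for which this assay gives 4 mg/kg, a gap that lies beyond the scatter. Compound 3 `Cc1ccccc1-c1nc(-c2ccc(N(C)C)cc2)n[nH]1` has not yet been measured; relative to compound 1 it carries dimethylamino in place of methyl on an aromatic carbon. Going by the values given here, no measured pair shows this change, so the step can only be guessed; a modest move toward a lower number is expected, as a 2.0-fold lower number from compound 1 to compound 3 (0.30 log units; within the scatter). For compound 3 the expected value in this assay is 10 mg/kg, within 3 mg/kg to 40 mg/kg.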

Compound 3, dose for half-maximal effect: 10 mg/kg
The estimate for compound 3 equals the measured number at the digits printed; the range from low to high includes it.
By their numbers in this assay, from the lowest: compound 2; then compounds 3 and 1 (each within the scatter of the next).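

In this assay, placing dimethylamino in place of methyl on the aromatic carbon para to a large group gives a 2.0-fold lower number from compound 1 to compound 3 (0.30 log units; within the scatter). This position therefore holds a group with more heavy atoms, including a nitrogen and a hydrogen-bond acceptor, without the number moving beyond the scatter. No measured property bears on this result, so it remains an observation without an explanation. The compounds shown leave open how a primary amine, a methoxy group or a carboxylic acid would read at this position in this assay.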